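A few compounds are considered here, and "the series" means these few. Any claim that something is new, unique, unknown or untested is made for them only; others in the source may bear on it.

Measured compounds:
Compound 1, `O=[N+]([O-])c1cn2c(n1)OC[C@@H](OCc1ccc(-c3ccc(OC(F)(F)F)cc3)cc1F)C2`, gives 85% in an ADME assay (liver, Mus musculus, strain CD1) for metabolic stability, using microsomes, with a stated time of 1 h; on this read-out higher numbers stand for a more stable compound and lower numbers for a less stable compound.
Compound 2, `N#Cc1cc(-c2ccc(OC(F)(F)F)cc2)ccc1CO[C@@H]1COc2nc([N+](=O)[O-])cn2C1`, gives 88% in this assay.
Compound 3, `O=[N+]([O-])c1cn2c(n1)OC[C@@H](COc1ccc(OC(F)(F)F)cc1)C2`, gives 80% in this assay.

Compound 3 sits within the scatter of both other compounds: its gap to compound 1 and its gap to compound 2 are each inside the usual spread of repeated measurements, so none of the three can be set apart from the others on this assay. Going by the values given here, the only single-point step among the measured compounds is a number 3 percentage points higher from compound 1 to compound 2 (within the scatter), and it concerns a change of substituent on an aromatic carbon.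

Compound 4, `O=[N+]([O-])c1cn2c(n1)OC[C@H](COc1ccc(OC(F)(F)F)cc1)C2`, is the partner of compound 3 in which (the two compounds have the same atoms and bonds and differ only in configuration as drawn: 1 of 1 stereo elements differ; a stereocentre at a saturated ring carbon is drawn R in compound 3 and S in compound 4). Among the compounds with values here, no measured step concerns a change of configuration alone, so nothing in the data bears directly on this move; the only measured step, a number 3 percentage points higher from compound 1 to compound 2 (within the scatter), stayed within the scatter and addressed a different kind of change. For compound 4 the expected step is therefore no change at the digits printed from compound 3 to compound 4 (within the scatter), none beyond the scatter. Compound 4 is estimated at 80%, between 65% and 92%.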

Compound 4, percent of the compound remaining: 72%
Beside the measured number, compound 4's estimate is 8 percentage points above it, and the stated range covers the measured number.
By their numbers in this assay, from the lowest: compounds 4, 3, 1 and 2 (each within the scatter of the next, the first and the last beyond it).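

In this assay, going by these compounds alone, a change of configuration alone now has a measured step of its own, a number 8 percentage points lower from compound 3 to compound 4 (within the scatter), whereas the earlier compounds offered only a substituent change on an aromatic carbon. The step stays within the usual spread of repeated measurements, so the stereocentre at this saturated ring carbon, drawn R or S, cannot be said to separate the two compounds on this read-out. Whatever gap there is has only one possible source within this pair: the fact that compounds 3 and 4 differ only in the configuration as drawn.

The compounds shown leave open whether configuration at this carbon would count for more with the side chain of compound 1 or compound 2. They also leave open how an amine or a carboxylic acid in place of the trifluoromethoxy group would read in this assay.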